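Aryl methoxy removal in a thioether-linked series

This account rests on a few compounds, and the source may have more. Where it says the series, first, only, none or still open, it means among the compounds named here.

Measured so far:
compound 1 `Cc1nc(-c2ccc(Cl)cc2)sc1C(=O)CSc1nc(-c2cccc(Cl)c2)c(C#N)c(=O)[nH]1` — 12.5%
compound 2 `COc1ccc(-c2nc(SCC(=O)c3sc(-c4ccc(Cl)cc4)nc3C)[nH]c(=O)c2C#N)cc1OC` — 18.7%

In a functional assay on U-87MG ATCC cells for antiproliferative activity against U-87 MG (Homo sapiens), read by MTT assay, with a stated time of 48 h, tested at 100 uM (a higher number here means a weaker effect of the compound at the concentration tested, a lower number a stronger effect), compound 1 gives 12.5% and compound 2 gives 18.7%. Compound 2 is separated from compound 1 only by a number 6.2 percentage points higher from compound 1 to compound 2 (within the scatter), which is within the scatter, so the two stand together.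

Compound 3 `COc1cccc(-c2nc(SCC(=O)c3sc(-c4ccc(Cl)cc4)nc3C)[nH]c(=O)c2C#N)c1` differs from compound 2 by hydrogen in place of methoxy on an aromatic carbon. Among the compounds with values here, the single measured step, a number 6.2 percentage points higher from compound 1 to compound 2 (within the scatter), also alters this aryl group and stays within the scatter, so no change beyond the scatter is expected in this assay. Compound 3 is therefore estimated at 15% (range 5% to 30%). For compound 3 this means an expected step of a number 3.7 percentage points lower from compound 2 to compound 3 (within the scatter), within the scatter.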

Compound 3, a percentage reported as activity, at one concentration (the size of the read-out at that concentration, not a potency): 8.54%
Beside the measured number, compound 3's estimate is 6.5 percentage points above it; the measured number falls inside the stated range.
By their numbers in this assay, from the lowest: compounds 3, 1 and 2 (each within the scatter of the next, the first and the last beyond it).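

In this assay, within the data shown here, the change from 3,4-dimethoxyphenyl to 3-methoxyphenyl gives a number 10.2 percentage points lower from compound 2 to compound 3 (beyond the scatter) and is the first step to pass the scatter, though only modestly. Methoxy in place of chloro on an aromatic carbon gives a number 4 percentage points lower from compound 1 to compound 3 (within the scatter) and so leaves compound 1 and compound 3 standing together. Nothing at hand accounts for either step.

As far as these compounds go, whether a hydroxyl or an amine in place of the remaining methoxy would shift the number stays open. So does whether this step holds in other cell lines.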